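From naphthalen-1-yl to 4-fluorophenyl at one concentration

The compounds below may be only part of what the source reports. "The series", "measured", "known", "first", "only" and "open" are said of these compounds alone.

Compound 1 `Cc1ccc(S(=O)(=O)Oc2ccccc2/C=C(\C#N)C(=O)Nc2nnc(Cc3cccc4ccccc34)s2)cc1`: 19%
Compound 2 `N#C/C(=C\c1ccccc1OS(=O)(=O)c1ccc(F)cc1)C(=O)Nc1nnc(Cc2cccc3ccccc23)s1`: 12%

In a functional assay on HL-60 cells (Homo sapiens) for inhibition, read by CCK-8 assay, with a stated time of 48 h, tested at 20 uM (on this read-out lower numbers stand for less inhibition of growth and higher numbers for more inhibition of growth at the one concentration tested), compound 2 gives 12%, which lies within the scatter of compound 1 at 19%, so the two cannot be ranked. Compound 3 `N#C/C(=C\c1ccccc1OS(=O)(=O)c1ccc(F)cc1)C(=O)Nc1nnc(Cc2ccc(F)cc2)s1` keeps the rest of compound 2 and carries a single change: 4-fluorophenyl in place of naphthalen-1-yl on a saturated chain carbon bound to an aromatic carbon. In words, 4-fluorophenyl stands in place of naphthalen-1-yl on a saturated chain carbon bound to an aromatic carbon. Going by the values given here, the only measured step, a number 7 percentage points lower from compound 1 to compound 2 (within the scatter), concerns another change, fluoro in place of methyl on an aromatic carbon. Among the compounds with values here, no measured step touches the naphthalen-1-yl group, so the data give no direction for this change, and nothing beyond the scatter is expected. The expected step is a number 1 percentage points higher from compound 2 to compound 3 (within the scatter). In this assay the value expected for compound 3 is 13%, with an estimated range from 3% to 28%.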

Compound 3, percent growth inhibition at one concentration: 13%
For compound 3 middle estimate and measured number coincide at the digits printed, within the range that was stated.
By their numbers in this assay, from the lowest: compounds 2, 3 and 1 (each within the scatter of the next).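

In this assay, going by these compounds alone, the first measured change at this position reads as a number 1 percentage points higher from compound 2 to compound 3 (within the scatter) and so stays within the scatter. At this place on a saturated chain carbon bound to an aromatic carbon, the two aromatic rings of naphthalen-1-yl and the single ring of 4-fluorophenyl therefore cannot be told apart, and compound 2 and compound 3 cannot be ranked. No measurement is at hand that would explain this result.

Going by these compounds, what remains open is whether any group at this place can move the number beyond the scatter, for instance 4-aminobenzyl, 4-carboxybenzyl or a longer chain ending in a phenyl ring. On these data alone, it is also open whether the methyl-for-fluoro exchange on the sulfonate aryl ring would read the same with 4-fluorobenzyl present.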